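Chloro for hydrogen on the aryl ring of compound 2

This account rests on a few compounds, and the source may have more. Where it says the series, first, only, none or still open, it means among the compounds named here.

The three compounds share a core, shown for compound 1 as `COc1cc(/C=C2\SC(=O)NC2=O)ccc1OCN1C(=O)c2ccccc2C1=O`, for compound 2 as `O=C1NC(=O)/C(=C/c2ccc(OCN3C(=O)c4ccccc4C3=O)cc2)S1` and for compound 3 as `O=C1NC(=O)/C(=C/c2cc([N+](=O)[O-])ccc2OCN2C(=O)c3ccccc3C2=O)S1`. In an assay on isolated protein for inhibition of Alpha glucosidase (Homo sapiens), read by spectrophotometry, with stated times of 15 min and 30 min (a lower number here means a stronger inhibitor, a higher number a weaker inhibitor), compound 1 gives 35100 nM, compound 2 gives 25600 nM and compound 3 gives 50500 nM; all three numbers lie within the scatter of one another, so compound 2 cannot be set apart from the others. Among the measured compounds shown here, the only single-point step measured, a 1.4-fold lower number from compound 1 to compound 2 (0.14 log units; within the scatter), shows that a change on the aromatic ring left the number essentially unchanged. Compound 4, `O=C1NC(=O)/C(=C/c2ccc(OCN3C(=O)c4ccccc4C3=O)c(Cl)c2)S1`, carries chloro in place of hydrogen on an aromatic carbon, ortho to a large group and meta to a group of 8 heavy atoms. For the measured compounds named here, with only one comparable step, and that one within the scatter, no movement beyond the scatter is expected in this assay for compound 4. Compound 4 is therefore expected to give about 24000 nM, with a range from 10000 nM to 58000 nM. For compound 4 this expectation amounts to a 1.1-fold lower number from compound 2 to compound 4 (0.03 log units; within the scatter).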

Compound 4, half-maximal inhibitory concentration: 21000 nM
Estimate against measurement, compound 4: 1.1-fold (0.06 log units) above; measured number inside the range.
By their numbers in this assay, from the lowest: compounds 4, 2, 1 and 3 (each within the scatter of the next, the first and the last beyond it).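

In this assay, chloro in place of hydrogen on an aromatic carbon, ortho to a large group and meta to a group of 8 heavy atoms, gives a step that stays within the scatter (a 1.2-fold lower number from compound 2 to compound 4 (0.09 log units; within the scatter)). Chloro in place of methoxy at the same carbon also stays within the scatter (a 1.7-fold lower number from compound 1 to compound 4 (0.22 log units; within the scatter)), so hydrogen, methoxy and chloro, three groups rather than the earlier two, now cannot be told apart at this position. Nothing measured on these compounds speaks to why this position tolerates these changes.

What the compounds shown leave open is whether an amine or a carboxylic acid on this carbon would move the number beyond the scatter. From the compounds shown here alone, whether bromine would behave as chloro does also remains open.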